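The compounds below may be only part of what the source reports. "The series", "measured", "known", "first", "only" and "open" are said of these compounds alone.

In a functional assay on KM12 cells (Homo sapiens) for antiproliferative activity (a higher number here means a weaker inhibitor of growth, a lower number a stronger inhibitor of growth), three compounds sharing one core have been measured. Compound 1 `COc1ccc(-c2nc3cc(F)ccc3s2)cc1Br` gives 6700 nM, compound 3 `CCOc1cc(-c2nc3cc(F)ccc3s2)ccc1OC` gives 5420 nM, and compound 2 `COc1ccc(-c2nc3cc(F)ccc3s2)cc1OC` gives 290 nM, the lowest number of the three. Compound 4 `COc1ccc(-c2nc3cc(Br)ccc3s2)cc1OC` has not yet been measured. Its difference from compound 2 is bromo in place of fluoro on an aromatic carbon, which is bromo in place of fluoro on an aromatic carbon.

Going by the values given here, no measured step touches the fluoro group, so the data offer only indirect guidance. Changes to other groups show how far a single swap can move the number: the measurements give a 23-fold lower number from compound 1 to compound 2 (1.36 log units; beyond the scatter) and a 19-fold higher number from compound 2 to compound 3 (1.27 log units; beyond the scatter), both large, whereas a 1.2-fold lower number from compound 1 to compound 3 (0.09 log units; within the scatter) shows almost no movement. Among the compounds with values here, compound 2 holds the lowest number so far, and the one step leading away from it, a 19-fold higher number from compound 2 to compound 3 (1.27 log units; beyond the scatter), went upward. A moderate rise in this assay is therefore expected, smaller than those large steps but quite uncertain. The expected change is a 2.4-fold higher number from compound 2 to compound 4 (0.38 log units; beyond the scatter). For compound 4 the estimated value is 700 nM, with an expected range of 150 nM to 3500 nM.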

Compound 4, concentration for 50% growth inhibition: 65200 nM
For compound 4 the middle estimate is 93-fold (1.97 log units) below the measured one; measured number outside the range, above it.
By their numbers in this assay, from the lowest: compound 2; then compounds 3 and 1 (each within the scatter of the next); then compound 4.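

In this assay, replacing fluoro with bromo gives a 220-fold higher number from compound 2 to compound 4 (2.35 log units; beyond the scatter), a larger step than any of the earlier swaps elsewhere on the shared core. Going by these compounds alone, this is the first evidence that this aromatic carbon matters, and it shows that the fluoro group cannot be exchanged freely for another halogen. The change swaps one heavy atom for one heavy atom and alters no ring, hydrogen-bond donor, hydrogen-bond acceptor or net charge, yet the number still climbs steeply, and no available evidence explains this.

On these data alone, with only fluoro and bromo at this carbon, it remains open whether the number would climb gradually or sharply across the groups in between, such as chloro, or how hydrogen, methyl or nitrile would behave there. As far as these compounds go, it is also open whether the same swap would have a similar effect alongside the ethoxy group of compound 3 or the bromo group of compound 1.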